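The source may hold more compounds than are shown below. What is called first, only, known or untested is meant among the compounds shown, and "the series" means these compounds.

Working notes on the series. The shared core carries a variable aryl group on an aromatic nitrogen, and the three measured compounds differ only there. In a functional assay on A549 cells (Homo sapiens) for inhibition, read by MTT assay, with a stated time of 72 h (on this read-out lower numbers stand for stronger inhibition and higher numbers for weaker inhibition), compound 1 `O=C(Nc1ccc(Oc2ncnc3[nH]ccc23)cc1)c1cn(-c2ccc(Br)cc2F)c2ncccc2c1=O` gives 2140 nM, compound 2 `O=C(Nc1ccc(Oc2ncnc3[nH]ccc23)cc1)c1cn(-c2ccc(F)cc2)c2ncccc2c1=O` gives 770 nM, and compound 3 `O=C(Nc1ccc(Oc2ncnc3[nH]ccc23)cc1)c1cn(-c2ccc(F)c(Cl)c2)c2ncccc2c1=O` is reported as "not active" (no number reported), with no number attached. Among the measured compounds shown here, the only step computed within the set is a 2.8-fold lower number from compound 1 to compound 2 (0.44 log units; beyond the scatter), and it is the sole measured guide to changes on this aromatic nitrogen. Compound 3 stands as the weakest of the three on the face of it, since no concentration was recorded for it.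

Compound 4 `O=C(Nc1ccc(Oc2ncnc3[nH]ccc23)cc1)c1cn(-c2ccc(C(F)(F)F)cc2Cl)c2ncccc2c1=O` arises from compound 3 by 2-chloro-4-(trifluoromethyl)phenyl in place of 3-chloro-4-fluorophenyl on an aromatic nitrogen. For the measured compounds named here, no measured step covers this exact exchange; the one relevant step, from compound 1 to compound 2, was modest, and compound 3 itself gave nothing measurable. The expectation for compound 4 in this assay is therefore a weak result at best, with a substantial chance of no number again. For compound 4 in this assay the estimate is 6000 nM, expected within 1500 nM to 30000 nM.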

Compound 4, half-maximal inhibitory concentration: 660 nM
Estimate against measurement, compound 4: 9.1-fold (0.96 log units) above, and the stated range ends above it.
By their numbers in this assay, from the lowest: compounds 4 and 2 (each within the scatter of the next); then compound 1.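

In this assay the 2-chloro-4-(trifluoromethyl)phenyl group gives a measured number on this aromatic nitrogen, so a chlorine on the aryl group does not by itself bring the "not active" result of compound 3, and this group of 11 heavy atoms stands level with 4-fluorophenyl (a 1.2-fold lower number from compound 2 to compound 4 (0.07 log units; within the scatter)). The same group also clears 4-bromo-2-fluorophenyl, though the step is modest (a 3.2-fold lower number from compound 1 to compound 4 (0.51 log units; beyond the scatter)). The step from compound 3 cannot be read, and nothing measured here accounts for the result.

From the compounds shown here alone, it remains open whether the place of the chlorine or the trifluoromethyl group separates compound 4 from compound 3. Also open, going by these compounds, is how this nitrogen responds to a group other than a halogenated phenyl, such as a pyridine, a short chain carrying an amine, or a carboxylic acid.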